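Amide nitrogen substituent swap: pyrrolidinylmethyl to dihydroxypropoxy

This account rests on a few compounds, and the source may have more. Where it says the series, first, only, none or still open, it means among the compounds named here.

Three compounds of this series have numbers in a functional assay on HT-29 cells (Homo sapiens) for antiproliferative activity; on this read-out higher numbers stand for weaker inhibition and lower numbers for stronger inhibition. Compound 1 `CC1(C)CNC(=O)c2sc(Nc3ccc(I)cc3F)c(C(=O)NC[C@H]3CCCN3)c2C1` gives 120 nM and stands lowest of the three. Compound 3 `CC1(C)CNC(=O)c2sc(Nc3ccc(I)cc3Cl)c(C(=O)NC[C@@H](O)CO)c2C1` gives 710 nM, and compound 2 `CNC(=O)c1c(Nc2ccc(I)cc2Cl)sc2c1CC(C)(C)CNC2=O` gives 1630 nM. Among the compounds with values here, the only single-point step among them is a 2.3-fold lower number from compound 2 to compound 3 (0.36 log units; beyond the scatter), so a dihydroxy-bearing chain on the saturated carbon attached to the amide nitrogen reads somewhat better than a bare hydrogen there.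

Compound 4 `CC1(C)CNC(=O)c2sc(Nc3ccc(I)cc3F)c(C(=O)NOC[C@H](O)CO)c2C1` has not yet been measured. Against compound 1 the change is 2,3-dihydroxypropoxy in place of (pyrrolidin-2-yl)methyl on an amide-type nitrogen. Within the data shown here, compound 1 and compound 3 differ in two places at once, so their values show only that compound 3 sits higher; they do not isolate the loss of the pyrrolidine. Among the measured compounds shown here, no measured compound carries an oxygen directly on the amide nitrogen, so that part of the change has no precedent here.

Taken together, the step from compound 2 to compound 3 argues that the diol end is acceptable, while the gap between compound 1 and compound 3 argues that leaving the pyrrolidine costs. The expected result for compound 4 is therefore a higher number than compound 1, a 4.2-fold higher number from compound 1 to compound 4 (0.62 log units; beyond the scatter). The estimate for compound 4 is 500 nM, with a range from 200 nM to 1300 nM.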

Compound 4, half-maximal inhibitory concentration: 1580 nM
Compound 4: middle estimate off by 3.2-fold (0.50 log units), on the low side, and the stated range ends below it.
By their numbers in this assay, from the lowest: compound 1; then compound 3; then compounds 4 and 2 (each within the scatter of the next).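

In this assay, within the data shown here, 2,3-dihydroxypropoxy in place of (pyrrolidin-2-yl)methyl on the amide-type nitrogen gives a 13-fold higher number from compound 1 to compound 4 (1.12 log units; beyond the scatter), a large step and the first read of this swap with the rest of compound 1 held fixed. The position therefore does not tolerate this exchange, even though both groups have the same number of heavy atoms, so that count alone does not set the activity here. The step joins three changes, namely the loss of the ring, the exchange of the ring nitrogen for oxygens and the placing of an oxygen directly on the amide-type nitrogen, and no measurement on hand assigns a cause to it.

Still open is how the step divides among these changes: a 2,3-dihydroxypropyl group, attached through carbon, would test the diol without the oxygen on the amide-type nitrogen, while a (pyrrolidin-2-yl)methoxy group would test that oxygen with the ring kept. Also open, from the compounds shown here alone, is whether the ring itself matters or only its amine, which a piperidin-2-ylmethyl group or an open-chain 2-aminoethyl group could address.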